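Cytotoxicity notes: methoxy to fluoro on the aryl series

The source may hold more compounds than are shown below. What is called first, only, known or untested is meant among the compounds shown, and "the series" means these compounds.

Measured in a functional assay on 8305C cells (Homo sapiens) for cytotoxicity, read by MTT assay, with a stated time of 24 h; a lower number here means a stronger inhibitor, a higher number a weaker inhibitor:
compound 1, `CCCc1cn([C@H]2C[C@H](CO)N(C)O2)nn1`, gives 5820 nM
compound 2, `COc1ccc(-c2cn([C@H]3C[C@H](CO)N(C)O3)nn2)cc1`, gives 8010 nM

Compound 2 has the higher of the two numbers, yet its gap to compound 1 lies within the scatter, so the two are not separated. Compound 3, `CN1O[C@@H](n2cc(-c3ccc(F)cc3)nn2)C[C@@H]1CO`, differs from compound 2 by fluoro in place of methoxy on an aromatic carbon. Among the measured compounds shown here, no comparable step exists among the measured compounds, so no direction can be read from them. The change is small in count and is expected to move this assay little: the step from compound 2 to compound 3 is estimated as a 1.0-fold lower number from compound 2 to compound 3 (0.00 log units; within the scatter), not beyond the scatter. Compound 3 is expected to give 8000 nM, within 3000 nM to 22000 nM.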

Compound 3, half-maximal inhibitory concentration: 6760 nM
Beside the measured number, compound 3's estimate is 1.2-fold (0.07 log units) above it; the range from low to high includes it.
By their numbers in this assay, from the lowest: compounds 1, 3 and 2 (each within the scatter of the next).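

In this assay, among the compounds shown here, the first single-place step gives a 1.2-fold lower number from compound 2 to compound 3 (0.07 log units; within the scatter). On an aromatic carbon para to a large group, methoxy and fluoro are therefore not separated, and this one exchange gives no direction for the position. No measured evidence bears on why this is so.

As far as these compounds go, whether any group at this position can separate from these two remains open, for instance an amine or a carboxylic acid in this assay. A single step also leaves open whether other aryl substituents would behave alike.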